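Working notes: cyclohexyl in place of sec-butyl

The source may hold more compounds than are shown below. What is called first, only, known or untested is meant among the compounds shown, and "the series" means these compounds.

Measured compounds:
compound 1 `CC(C)CC1OCCC(Cl)=C1[Si](C)(C)C`, in a functional assay on SW1573 cells (Homo sapiens) for antiproliferative activity (on this read-out higher numbers stand for weaker inhibition of growth and lower numbers for stronger inhibition of growth), compound 1 gives 10000 nM
compound 2 `CCC(C)[C@H]1O[C@@H](C)CC(Cl)=C1[Si](C)(C)C`, in this assay compound 2 gives > 100000 nM

Compound 2 stands at the edge of what the read-out reports: its entry is a limit of the assay and not a number, as the limit of > 100000 nM in this assay, at which 1 of the 2 values shown sits, records. Compound 1 carries a number on the same read-out, but the two structures differ in more than one place, so nothing is drawn from the pair beyond the two values themselves.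

Compound 3 `C[C@H]1CC(Cl)=C([Si](C)(C)C)[C@@H](C2CCCCC2)O1` is the next member to be measured. It differs from compound 2 in one place: cyclohexyl in place of sec-butyl on a saturated ring carbon. Among the compounds with values here, no measured step of the same kind exists, so the size of the effect is open. The expectation is a step from compound 2 to compound 3 of modest size, if any, with the result likely to stay weak; the expected shift is an at least 2.0-fold lower number from compound 2 to compound 3 (0.30 log units; that floor lies within the scatter). For compound 3 the estimate in this assay is 50000 nM, with a range from 10000 nM to 200000 nM.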

Compound 3, concentration for 50% growth inhibition: 16000 nM
Compound 3: middle estimate off by 3.1-fold (0.49 log units), on the high side, and the stated range covers the measured number.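

In this assay, within the data shown here, cyclohexyl in place of sec-butyl on a saturated ring carbon, next to the ring oxygen, gives an at least 6.2-fold lower number from compound 2 to compound 3 (0.79 log units; beyond the scatter), the first measured single-place step and one showing that the read-out responds to the group at this position. The size of that step is only a floor, as the entry for compound 2 is a limit of the assay and not a number: the limit of > 100000 nM in this assay, at which 1 of the 3 values shown sits. Compound 3 gives 16000 nM, a number rather than a limit, so further changes at this position can be read from it as sized steps, which compound 2 does not allow.

Going by these compounds, one step cannot separate the ring from the carbon count, as cyclohexyl differs from sec-butyl in both, so it remains open whether an open chain of six carbons, such as n-hexyl, would give the same result as cyclohexyl. On these data alone, it also remains open how phenyl or a chain ending in an amine would read at this position, and whether the shift seen here would carry over to the core of compound 1, which has no methyl group on the ring.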